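Working notes: aryl ether variation and maximal response

The compounds below may be only part of what the source reports. "The series", "measured", "known", "first", "only" and "open" are said of these compounds alone.

The three measured compounds share a core in which a tert-butoxycarbonyl-protected piperidine is joined through an ether to a cyclohexane ring that carries a second ether to an aromatic group. Compound 1 `CC(C)(C)OC(=O)N1CCC(O[C@H]2CC[C@H](Oc3ccc(S(C)(=O)=O)c(F)c3)CC2)CC1` carries a fluorinated methylsulfonylphenyl group; in a functional assay on isolated protein for agonist activity at Glucose-dependent insulinotropic receptor (Rattus norvegicus), read by HTRF and cAMP accumulation (on this read-out higher numbers stand for larger maximal responses and lower numbers for smaller maximal responses), compound 1 gives 109%. Compound 2 `CC(C)(C)OC(=O)N1CCC(O[C@H]2CC[C@H](Oc3ccc(C#N)cc3)CC2)CC1` carries a 4-cyanophenyl group, and in this assay compound 2 gives 106%. Compound 3 `Cc1nc(O[C@H]2CC[C@H](OC3CCN(C(=O)OC(C)(C)C)CC3)CC2)ccc1C(=O)N(C)C` carries a dimethylamide-bearing methylpyridine, and in this assay compound 3 gives 111%. On these numbers compound 2 cannot be told apart from compound 1 or compound 3: both gaps lie within the scatter, so the three compounds behave as full agonists of comparable maximal response.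

Compound 4 `CC(C)(C)OC(=O)N1CCC(O[C@H]2CC[C@H](Oc3ccc(S(C)(=O)=O)nn3)CC2)CC1` follows from compound 2 by the change (6-(methylsulfonyl)pyridazin-3-yl in place of 4-cyanophenyl on an oxygen on a saturated carbon). Going by the values given here, no measured pair in this set isolates this change, so the expectation rests on the three values alone. The step of a number 2 percentage points higher from compound 2 to compound 4 (within the scatter) is expected to be none beyond the scatter, because compound 1 with its own methylsulfonyl-bearing ring gives 109%. Compound 4 is therefore estimated to give 108%, with a range from 95% to 120%.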

Compound 4, largest response reached (Emax), in percent of the reference or control that the assay uses: 86%
Compound 4: the middle estimate sits 22 percentage points above what was measured; measured number outside the range, below it.
By their numbers in this assay, from the lowest: compound 4; then compounds 2, 1 and 3 (each within the scatter of the next).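

In this assay, going by these compounds alone, the group on an oxygen on a saturated carbon is not interchangeable for maximal response: a number 20 percentage points lower from compound 2 to compound 4 (beyond the scatter) is the first step that lies beyond the scatter. The methylsulfonyl group alone does not fix the level, as compound 1, with its fluorinated methylsulfonylphenyl group, gives 109%, whereas compound 4, with 6-(methylsulfonyl)pyridazin-3-yl, gives 86%, so these two compounds share that group but not its ring. Nothing in the data available accounts for the lower response.

The compounds shown leave open whether the lower response follows the six-membered aromatic ring with two hetero atoms or its pairing with methylsulfonyl, a question that a 6-cyanopyridazin-3-yl group and an unfluorinated 4-(methylsulfonyl)phenyl group on the same oxygen would separate. Also open, on these data alone, is whether the step from the 4-cyanophenyl group to the 6-(methylsulfonyl)pyridazin-3-yl group keeps its size when the tert-butoxycarbonyl group on the piperidine is replaced by a simple amide or a free amine.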